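The source may report more compounds than this note shows. Statements on the series, on what has been measured and on what is new or still open speak of the compounds shown alone.

Compound 1 `COC(=O)C[C@@H]1CCCN1CCC/C=C1\C=C(C)C(=O)O1`: > 5 ug/mL
Compound 2 `COC(=O)C[C@H]1CCCN1CCC/C=C1\C=C(C)C(=O)O1`: > 5 ug/mL

In a functional assay on A549 cells (Homo sapiens) for cytotoxicity (a lower number here means a stronger inhibitor, a higher number a weaker inhibitor), compound 2 gives > 5 ug/mL, which is a limit of the assay and not a number. Compound 1 gives > 5 ug/mL, which is also a limit. All that is known, then, is that neither compound reached half-maximal inhibition within the tested range.

Compound 3 `COC(=O)C[C@H]1CCCN1CCC/C=C1/C=C(C)C(=O)O1` is the next structure to be tested, and it relates to compound 2 in this way: the two compounds have the same atoms and bonds and differ only in configuration as drawn: 1 of 2 stereo elements differ; a double bond is drawn E in compound 2 and Z in compound 3. Only the double bond changes, and the stereocentre stays as drawn in compound 2.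

Going by the values given here, the one measured step that bears on this is also a change of configuration, though at a saturated ring carbon rather than at the double bond: a step that the two limits leave unreadable from compound 1 to compound 2. Its size cannot be read because of the limit of > 5 ug/mL in this assay, at which 2 of the 2 values shown sit. It therefore offers no evidence of a shift in either direction, and no step beyond the usual scatter is expected. The estimated step is a step that the limit leaves unreadable from compound 2 to compound 3. The most likely report is another limit. For compound 3 the expected value is estimated at 7 ug/mL, with a range from 3 ug/mL to 15 ug/mL.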

Compound 3, half-maximal inhibitory concentration: > 5 ug/mL
Compound 3 ended at the assay's limit (the forecaster's own chance of this, stated with the estimate: 75%); the middle value lies beyond the limit too.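

No step among compound 1, compound 2 and compound 3 can be read, and a single fact accounts for this: the limit of > 5 ug/mL in this assay, at which 3 of the 3 values shown sit.

The compounds shown leave open how far beyond that limit each of the three lies in this assay, and whether the configuration at the ring stereocentre or at the double bond makes any difference there.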